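The source may hold more compounds than are shown below. What is called first, only, known or untested is meant among the compounds shown, and "the series" means these compounds.

Going by the values given here, compound 3, with the structure `O=C(O)CC[C@H](NC(=O)CN(c1nc(Cl)nc2[nH]cnc12)C1CC1)C(=O)O`, is one of three compounds measured in a functional assay on the whole organism (Tail, strain ICR) with Mus musculus as the target, in the tail flick test, with a stated time of 150 min, at a dose of 25 umol/kg by the oral route (a lower number here means a weaker effect, a higher number a stronger effect of the compound at the dose given), where compound 3 gives 29.5%. That places compound 3 second highest of the three. Compound 2, with the structure `O=C(CN(c1nc(Cl)nc2[nH]cnc12)C1CC1)N[C@@H](CCC(=O)OCc1ccccc1)C(=O)OCc1ccccc1`, gives 44.5% in this assay, a number beyond the scatter above compound 3, while compound 1, with the structure `N=C(N)NCCC[C@H](NC(=O)CN(c1nc(Cl)nc2[nH]cnc12)C1CC1)C(=O)OCc1ccccc1`, gives 6.12% in this assay, a number beyond the scatter below compound 3. Compound 2 and compound 3 differ in more than one place, so their two values can only be set side by side.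

Compound 4, with the structure `CSCC[C@H](NC(=O)CN(c1nc(Cl)nc2[nH]cnc12)C1CC1)C(=O)O`, is not yet measured. It differs from compound 3 by methylsulfanyl in place of carboxy on a saturated chain carbon, three bonds along the chain from an amide-type nitrogen and a carbonyl carbon. Among the compounds with values here, the single step measured so far at this same position is a number 38.4 percentage points higher from compound 1 to compound 2 (beyond the scatter), a large step, though it exchanges different groups. It shows that a change at this position can move the read-out strongly in either direction, but it gives no pointer for the present exchange. He therefore expects a step of a number 2.5 percentage points higher from compound 3 to compound 4 (within the scatter) for compound 4, within the scatter, but with a wide band. His estimate for compound 4 in this assay is 32%, between 10% and 55%.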

Compound 4, a percentage reported as activity, at one dose (the size of the read-out at that dose, not a potency): 4.14%
For compound 4 the middle estimate is 27.9 percentage points above the measured one; the whole stated range lies above it.
By their numbers in this assay, from the lowest: compounds 4 and 1 (each within the scatter of the next); then compound 3; then compound 2.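

In this assay, the exchange of carboxy for methylsulfanyl on this saturated chain carbon gives a number 25.4 percentage points lower from compound 3 to compound 4 (beyond the scatter). The earlier step at this position, a number 38.4 percentage points higher from compound 1 to compound 2 (beyond the scatter), exchanged one group for a larger one that brought in an aromatic ring, so it could not show whether a small exchange would matter. Here neither group carries a ring and the heavy atom count shifts only from 3 to 2, yet the read-out still moves beyond the scatter, and in the downward direction, so this position responds to the identity of the group and not only to a large change in its size. Nothing at hand bears on why the read-out falls with this exchange.

The compounds shown leave open whether the fall follows from the departure of carboxy or from the arrival of the sulfur, which a plain alkyl chain such as propyl or an amine such as 2-aminoethyl in place of 2-carboxyethyl would help to separate. They also leave open how the step would look at another dose or time in this assay.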